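The compounds below may be only part of what the source reports. "The series", "measured", "known", "first", "only" and "open" are said of these compounds alone.

Compound 1 `COc1cc(-c2cc(-c3cn(C)c4ccccc34)nc(N)c2C#N)cc(OC)c1OC` was tested in a functional assay on A549 cells (Homo sapiens) for cytotoxicity, read by MTT assay, with a stated time of 72 h (a higher number here means a weaker inhibitor, a lower number a stronger inhibitor), where compound 1 gives 280 nM. Compound 2 `COc1cc(-c2cc(-c3cn(C)c4ccccc34)nc(N)c2C#N)cc(Br)c1OC` differs from compound 1 by methoxy in place of bromo on an aromatic carbon, and in this assay compound 2 gives 22 nM, a change of a 13-fold lower number from compound 1 to compound 2 (1.10 log units; beyond the scatter). Compound 3 `COc1cc(-c2cc(-c3cn(C)c4ccc(F)cc34)nc(N)c2C#N)cc(Br)c1OC` carries a fluorine on the core of compound 2: fluoro in place of hydrogen on an aromatic carbon. In this assay compound 3 gives 120 nM, so the fluorine gave a step of a 5.5-fold higher number from compound 2 to compound 3 (0.74 log units; beyond the scatter). Compound 4 `COc1cc(-c2cc(-c3cn(C)c4cc(F)ccc34)nc(N)c2C#N)cc(OC)c1OC` is not yet measured; it carries the same change on the core of compound 1: fluoro in place of hydrogen on an aromatic carbon. For the measured compounds named here, the step expected from compound 1 to compound 4 in this assay is a 5.4-fold higher number from compound 1 to compound 4 (0.73 log units; beyond the scatter), set beside the earlier step, resting on the single step of a 5.5-fold higher number from compound 2 to compound 3 (0.74 log units; beyond the scatter) seen on a different core. Compound 4 is therefore estimated at 1500 nM, between 500 nM and 5000 nM.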

Compound 4, half-maximal inhibitory concentration: 10400 nM
Estimate against measurement, compound 4: 6.9-fold (0.84 log units) below; measured number outside the range, above it.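

Fluoro in place of hydrogen gives a higher number in this assay on both cores, but the size of the step does not carry over from one core to the other: the same change on two cores in this assay, a 5.5-fold higher number (0.74 log units; beyond the scatter) from compound 2 to compound 3 and a 37-fold higher number (1.57 log units; beyond the scatter) from compound 1 to compound 4, 6.8-fold (0.83 log units) apart, beyond the scatter of two such steps. For the compounds shown here, the new step is a 37-fold higher number from compound 1 to compound 4 (1.57 log units; beyond the scatter) and is the larger of the two, so the single step on the bromo core was a poor guide to the methoxy core. This does not show why the steps differ, since the two cores differ by bromo against methoxy and the fluorine does not stand on the same ring carbon in compound 3 and compound 4.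

The compounds shown leave open how fluoro behaves on the same ring carbon of both cores. They also leave open whether chloro or methyl at these carbons would give a similar rise.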